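Notes on compounds 1 to 4: methoxy for methyl

The source may report more compounds than this note shows. Statements on the series, on what has been measured and on what is new or still open speak of the compounds shown alone.

Measured so far:
- Compound 1 `Cc1ccc(OS(=O)(=O)c2ccc(N3CCN(C)C3=O)cc2)cc1` in a functional assay on M21 cells (Homo sapiens) for antiproliferative activity, read by sulforhodamine B assay, with a stated time of 48 h (on this read-out higher numbers stand for weaker inhibition and lower numbers for stronger inhibition), gives > 100000 nM, a limit of the assay.
- Compound 2 `COc1ccc(OS(=O)(=O)c2ccc(N3CCN(C)C3=O)cc2)cc1` gives > 100000 nM, also a limit.
- Compound 3 `CCCN1CCN(c2ccc(S(=O)(=O)Oc3ccc(C)cc3)cc2)C1=O` gives 28000 nM, the only number in the set.

Compound 1 and compound 2 differ by methoxy in place of methyl on an aromatic carbon. The step that the two limits leave unreadable from compound 1 to compound 2 cannot be read, because both values sit at the limit of > 100000 nM in this assay, at which 2 of the 3 values shown sit. Compound 3 differs from compound 1 by ethyl in place of hydrogen on a saturated chain carbon bound to an amide-type nitrogen in a ring, and here the step of an at least 3.5-fold lower number from compound 1 to compound 3 (0.55 log units; beyond the scatter) is visible.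

Compound 4 `CCCN1CCN(c2ccc(S(=O)(=O)Oc3ccc(OC)cc3)cc2)C1=O` is the compound not yet measured. It differs from compound 3 by methoxy in place of methyl on an aromatic carbon, the same change as from compound 1 to compound 2, at the same place. That earlier step gave no readable size, so its transfer to compound 3 rests on nothing firmer than the likeness of the change. The expected step of a 1.3-fold higher number from compound 3 to compound 4 (0.10 log units; within the scatter) is therefore set small, with wide room either way. For compound 4 the expected value in this assay is 35000 nM, between 12000 nM and 100000 nM.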

Compound 4, half-maximal inhibitory concentration: 23000 nM
Beside the measured number, compound 4's estimate is 1.5-fold (0.18 log units) above it; measured number inside the range.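

In this assay, methoxy in place of methyl gives a 1.2-fold lower number from compound 3 to compound 4 (0.09 log units; within the scatter), so this change leaves no step beyond the scatter on this core. The other change, ethyl in place of hydrogen on the chain carbon, gives an at least 4.3-fold lower number from compound 2 to compound 4 (0.63 log units; beyond the scatter), and it can be set beside the earlier step on the other core: the same change on two cores in this assay, an at least 3.5-fold lower number (0.55 log units; beyond the scatter) from compound 1 to compound 3 and an at least 4.3-fold lower number (0.63 log units; beyond the scatter) from compound 2 to compound 4; the limit leaves it open whether they differ. It remains unshown whether methoxy for methyl behaves the same way on the core of compound 1, because the step between compound 1 and compound 2 cannot be read and the chain steps that start from a limit give only a bound: the limit of > 100000 nM in this assay, at which 2 of the 4 values shown sit.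

Still open, on these data alone, is whether a group other than methyl or methoxy on the same aromatic carbon, such as an amine or a carboxylic acid, would give a step beyond the scatter. Also open, as far as these compounds go, is whether a longer chain on the ring nitrogen would carry the number further in the direction of the chain steps.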